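Swapping a pyridine for a thiophene on a shared core

The source may report more compounds than this note shows. Statements on the series, on what has been measured and on what is new or still open speak of the compounds shown alone.

Measured compounds:
- compound 1 `Oc1cccc(-c2cc(-c3ccncc3)nc(-c3ccccc3Cl)c2)c1`: compound 1 is reported as "not determined" (no result reported) in a functional assay on T47D cells (Homo sapiens) for cytotoxicity, read by CCK-8 assay and cell counting, with a stated time of 2 days; a lower number here means a stronger inhibitor, a higher number a weaker inhibitor
- compound 2 `Oc1cccc(-c2cc(-c3ccncc3)nc(-c3cccc(Cl)c3)c2)c1`: compound 2 is reported as "not determined" (no result reported) in this assay
- compound 3 `Oc1cccc(-c2cc(-c3ccncc3)nc(-c3ccc(Cl)cc3)c2)c1`: compound 3 gives 3330 nM in this assay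

Compound 1 has no single number in this assay, and compound 2 is a further entry without one. Among the measured compounds shown here, only compound 3 carries a value, and no step between measured compounds is available, so nothing here shows how a change on the shared core moves the read-out.

Compound 4 `Oc1cccc(-c2cc(-c3cccs3)nc(-c3ccccc3Cl)c2)c1` differs from compound 1 in one place: thiophen-2-yl in place of pyridin-4-yl on an aromatic carbon. The change is thiophen-2-yl in place of pyridin-4-yl on an aromatic carbon of the core of compound 1.

Compound 1 has no number. For the measured compounds named here, no step size can therefore be taken from the data for this change in this assay, in either direction; the only anchor is the value of compound 3, and it is a different compound. Compound 4 is therefore expected, with wide uncertainty, to give about 3500 nM, estimated within a range from 800 nM to 16000 nM.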

Compound 4, half-maximal inhibitory concentration: 3990 nM
Beside the measured number, compound 4's estimate is 1.1-fold (0.06 log units) below it; the range from low to high includes it.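

Among the compounds shown here, compound 1 has no single number in this assay, and no step from it to compound 4 can be read. As far as these compounds go, what swapping pyridin-4-yl for thiophen-2-yl does to the read-out stays open, and no supporting finding bears on this result.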